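A few compounds are considered here, and "the series" means these few. Any claim that something is new, unique, unknown or untested is made for them only; others in the source may bear on it.

Compound 1 `CNC(=O)c1cc(C(=O)NC2CC2)cn(Cc2cccc(F)c2)c1=O`: >= 133 ug/mL (a limit)
Compound 2 `CNC(=O)c1cc(C(=O)NC2CC2)cn([C@H](C)c2ccccc2)c1=O`: >= 168 ug/mL (a limit)
Compound 3 `CNC(=O)c1cc(C(=O)NC)c(=O)n(Cc2ccccc2)c1`: >= 118 ug/mL (a limit)

Compound 2 has only a limit (>= 168 ug/mL) in a physicochemical assay for solubility (on this read-out lower numbers stand for lower solubility and higher numbers for higher solubility), and no exact number. The other two compounds likewise have only limits. Compound 4 (`CNC(=O)c1cc(C(=O)NC2CC2)cn(CC2CCCOC2)c1=O`) carries (oxan-3-yl)methyl in place of 1-phenylethyl on an aromatic nitrogen. Within the data shown here, the one measured step at that nitrogen is a step that the two limits leave unreadable from compound 1 to compound 2 and it is the only guide. Both its ends are limits, so it offers no size to carry over. The estimated change (an at least 1.1-fold lower number from compound 2 to compound 4 (0.04 log units; that floor lies within the scatter)) is therefore expected to stay within the usual scatter, with no direction favoured. A limit is again the likely result for compound 4. For compound 4 the expected value is 150 ug/mL with an estimated range from 90 ug/mL to 210 ug/mL here.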

Compound 4, solubility: >= 131 ug/mL
Compound 4: no number, only a limit; the forecaster's own chance of this, stated with the estimate: 75%; the middle value does not contradict the limit.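

In this assay, compound 4 has only a limit, as do compound 1 and compound 2, and no step among these compounds can be read. The compounds shown leave open whether (oxan-3-yl)methyl in place of 1-phenylethyl changes the read-out at all, and in which direction.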